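The source may hold more compounds than are shown below. What is called first, only, known or untested is meant among the compounds shown, and "the series" means these compounds.

Measured so far in an ADME assay on HEK-293T cells (Homo sapiens) for cytotoxicity, with a stated time of 48 h; on this read-out higher numbers stand for lower toxicity in this test and lower numbers for higher toxicity in this test:
compound 1, `CCc1ncnc(NC(C)c2ccc(NC(C)=O)cc2)c1Cl`, gives > 10000 nM
compound 2, `CCc1ncnc(NCc2ccc(C(C)(C)C)cc2)c1Cl`, gives > 10000 nM

Neither of these figures is a number in the ordinary sense. For compound 1 the value > 10000 nM is a limit of the assay. For compound 2 the value > 10000 nM is likewise a limit of the assay. So compound 2 stands exactly where the one other value stands: the whole picture is the limit of > 10000 nM in this assay, at which 2 of the 2 values shown sit. Among the compounds with values here, no pair of measured compounds here differs in a single place, so no measured step is available to carry over.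

Compound 3, `CCc1ncnc(NC(C)c2ccc(C(C)(C)C)cc2)c1Cl`, has not yet been measured. It differs from compound 2 in one place: methyl in place of hydrogen on a saturated chain carbon bound to an aromatic carbon and a nitrogen on an aromatic ring. The same methyl on the same chain carbon is already present in compound 1, and compound 1 sits at the limit. In this assay the expectation is therefore a step of no size beyond the scatter, in neither direction. Compound 3 is expected to give about 20000 nM, within 8000 nM to 60000 nM. That expectation corresponds to a step that the limit leaves unreadable from compound 2 to compound 3, and most likely the result will again be a limit rather than a number.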

Compound 3, half-maximal cytotoxic concentration: > 10000 nM
Compound 3 gave a limit, no number; the forecaster's own chance of this, stated with the estimate: 85%; the middle value lies beyond the limit too.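

Compound 3 gives a limit of the assay and not a number, so the steps from compound 2 and from compound 1 to compound 3 cannot be read, because all three compounds sit at the same limit in this assay: the limit of > 10000 nM in this assay, at which 3 of the 3 values shown sit.

The compounds shown leave open whether methyl in place of hydrogen, or tert-butyl in place of acetamido, changes this read-out at all.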